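The source may hold more compounds than are shown below. What is called first, only, known or untested is meant among the compounds shown, and "the series" means these compounds.

Series notes. Within the data shown here, the shared core carries a phenyl group; in compound 1 `NS(=O)(=O)NCC1CCN(c2cc(-c3ccccc3)ncn2)CC1` that phenyl is unsubstituted, and in a functional assay on MCF7 cells (Homo sapiens) for antiproliferative activity, read by sulforhodamine B assay, with a stated time of 48 h (a lower number here means a stronger inhibitor of growth, a higher number a weaker inhibitor of growth), compound 1 gives 34300 nM, the highest of the three numbers so far. Compound 2 `CC(C)(C)c1ccc(-c2cc(N3CCC(CNS(N)(=O)=O)CC3)ncn2)cc1` gives 19700 nM in this assay, and compound 3 `CCOC(=O)c1ccc(-c2cc(N3CCC(CNS(N)(=O)=O)CC3)ncn2)cc1` gives 4100 nM. The two measured steps from compound 1 are therefore a 1.7-fold lower number from compound 1 to compound 2 (0.24 log units; within the scatter), and an 8.4-fold lower number from compound 1 to compound 3 (0.92 log units; beyond the scatter). Between the two substituted compounds, a 4.8-fold lower number from compound 2 to compound 3 (0.68 log units; beyond the scatter).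

Compound 4 `NS(=O)(=O)NCC1CCN(c2cc(-c3cccc(Cl)c3)ncn2)CC1` differs from compound 1 by chloro in place of hydrogen on an aromatic carbon: one heavy atom, no ring, no hydrogen-bond donor or acceptor, sitting meta to a large group. Among the measured compounds shown here, no measured step places a group at that position, so the only bearing comes from the two substitutions of the phenyl already seen: the tert-butyl step stayed within the scatter, and the ethoxycarbonyl step gave a modest improvement. A chloro substituent is expected to fall between these two outcomes, and the step from compound 1 to compound 4 is estimated at a 2.3-fold lower number from compound 1 to compound 4 (0.36 log units; beyond the scatter). Compound 4 is accordingly expected to give about 15000 nM in this assay, within a range of 5000 nM to 40000 nM.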

Compound 4, concentration for 50% growth inhibition: 47100 nM
Compound 4: the middle estimate sits 3.1-fold (0.50 log units) below what was measured, outside the stated range (above it).
By their numbers in this assay, from the lowest: compound 3; then compounds 2, 1 and 4 (each within the scatter of the next, the first and the last beyond it).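

In this assay, among these compounds, the first reading for a substituent meta to a large group on the phenyl is a 1.4-fold higher number from compound 1 to compound 4 (0.14 log units; within the scatter), so 3-chlorophenyl cannot be told apart from phenyl. Substitution of the phenyl therefore does not by itself lower the number: among the three substituted compounds, only the ethoxycarbonyl step, an 8.4-fold lower number from compound 1 to compound 3 (0.92 log units; beyond the scatter), lies beyond the scatter, while compound 2 and compound 4 both remain within it of compound 1. No measurement at hand accounts for the chloro result.

The compounds shown do not separate the identity of the group from its place on the ring, since ethoxycarbonyl has not been seen meta to a large group and chloro has not been seen anywhere else on the phenyl. A carboxylic acid, a primary amide or an amine in the same place would test whether the lower number of compound 3 extends beyond the ethyl ester, and fluoro or methoxy would show whether the flat chloro step holds for other small groups.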